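Difluoromethoxy in Place of Chloro at a Shared Limit

The source may report more compounds than this note shows. Statements on the series, on what has been measured and on what is new or still open speak of the compounds shown alone.

Compound 1 `OC[C@H]1O[C@@H](n2cnc3c(NCc4ccccc4Cl)ncnc32)[C@H](O)[C@@H]1O` is tested in a functional assay on HOS cells (Homo sapiens) for antiproliferative activity, with a stated time of 72 h (on this read-out lower numbers stand for stronger inhibition and higher numbers for weaker inhibition), where compound 1 gives only a limit, > 166000 nM. Compound 2 `OC[C@H]1O[C@@H](n2cnc3c(NCc4ccc(Cl)c(Cl)c4)ncnc32)[C@H](O)[C@@H]1O` likewise reaches only a limit in this assay, > 166000 nM. Compound 3 `OC[C@H]1O[C@@H](n2cnc3c(NCc4ccc(F)cc4F)ncnc32)[C@H](O)[C@@H]1O` also stops at a limit, > 166000 nM. Hence a step that the two limits leave unreadable from compound 1 to compound 2 and a step that the two limits leave unreadable from compound 1 to compound 3 cannot be sized, and a step that the two limits leave unreadable from compound 2 to compound 3 is equally unreadable. Compound 4 `OC[C@H]1O[C@@H](n2cnc3c(NCc4ccccc4OC(F)F)ncnc32)[C@H](O)[C@@H]1O` differs from compound 1 by difluoromethoxy in place of chloro on an aromatic carbon. Among the measured compounds shown here, no measured step touches a difluoromethoxy group, and because the limit of > 166000 nM in this assay, at which 3 of the 3 values shown sit, holds every value shown, compound 4 is expected to stay at that limit as well, an estimated step of a number no higher from compound 1 to compound 4 (the limit leaves the size open). Compound 4 is therefore estimated at 166000 nM, with a range from 40000 nM to 600000 nM.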

Compound 4, half-maximal inhibitory concentration: > 166000 nM
Compound 4 was reported as a limit; the forecaster's own chance of this, stated with the estimate: 85%; the middle value sits exactly at the limit.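

Compound 4 also stops at a limit in this assay, > 166000 nM. Its steps from compound 1, compound 2 and compound 3 cannot be read. The compounds shown leave open which change to the shared core, if any, would give a readable value in this assay.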